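The compounds below may be only part of what the source reports. "The series", "measured", "known", "first", "only" and "open" are said of these compounds alone.

Compounds measured so far:
compound 1, `CCCCCCCCc1cc2cn(C3CCC(CO)O3)c(=O)nc2o1`: > 112000 nM
compound 2, `CCCCCCCCCc1cc2cn(C3CCC(CO)O3)c(=O)nc2o1`: > 200000 nM

In a functional assay on HEL cells (Homo sapiens) (a lower number here means that less compound is tolerated, a higher number that more compound is tolerated), compound 1 gives > 112000 nM, which is a limit of the assay and not a number. That is all that fixes where compound 1 stands: only the limit of > 112000 nM in this assay, at which 1 of the 2 values shown sits, is known for it. In this assay compound 2 likewise gives > 200000 nM, again a limit. The step that the two limits leave unreadable from compound 1 to compound 2 therefore cannot be read, as the limit of > 200000 nM in this assay, at which 1 of the 2 values shown sits, shows.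

The unmeasured compound 3, `CCCCCCCCCCCc1cc2cn(C3CCC(CO)O3)c(=O)nc2o1`, differs from compound 1 by propyl in place of hydrogen on a saturated chain carbon, eight bonds along the chain from an aromatic carbon. Among the compounds with values here, the only measured step that bears on this change is the one from compound 1 to compound 2, and its size is not readable, so no direction beyond the scatter can be expected in this assay. Compound 3 is accordingly expected to give 150000 nM, with a range of 60000 nM to 400000 nM, most probably again as a limit. The estimated step that the limit leaves unreadable from compound 1 to compound 3 is expected to stay within the scatter.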

Compound 3, half-maximal cytotoxic concentration: > 200000 nM
Compound 3 ended at the assay's limit; the forecaster's own chance of this, stated with the estimate: 75%; middle value at least 1.3-fold (0.12 log units) away from the limit.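

In this assay compound 3 gives > 200000 nM, again a limit and not a number. Within the data shown here, no step from compound 1 or compound 2 to compound 3 can be read. The compounds shown leave open where the half-maximal cytotoxic concentration of any of the three lies.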